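The compounds below may be only part of what the source reports. "The series", "measured", "known", "first", "only" and "open" are said of these compounds alone.

Working notes on the series built on the shared core, read in an ADME assay on BCBL1 cells (Homo sapiens) for cytotoxicity, with a stated time of 7 days; a higher number here means that more compound is tolerated, a lower number that less compound is tolerated. Compound 1 `CCOc1nc(N)nc2c1ncn2/C=C1/CC1(CO)CO` gives > 20000 nM, which is a limit. Compound 2 `CC(C)Nc1nc(N)nc2c1ncn2/C=C1/CC1(CO)CO` gives > 20000 nM, which is also a limit. Going by the values given here, compound 3 `Nc1nc(NC2CC2)c2ncn(/C=C3/CC3(CO)CO)c2n1` gives 71500 nM, the only actual number among the three. The remaining reference point is the limit of > 20000 nM in this assay, at which 2 of the 3 values shown sit, and nothing finer.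

Compound 4 `CCCCCCCCSc1nc(N)nc2c1ncn2/C=C1/CC1(CO)CO` differs from compound 3 by octylsulfanyl in place of cyclopropylamino on an aromatic carbon.

The measured steps offer no size to carry over: a step that the two limits leave unreadable from compound 1 to compound 2 and a step that the limit leaves unreadable from compound 1 to compound 3 and a step that the limit leaves unreadable from compound 2 to compound 3 all stay unreadable. None of them brings in octylsulfanyl either, and all three concern amino or ethoxy groups at this same place. Among the compounds with values here, with no measured step to scale from, the expectation starts from compound 3 at 71500 nM and no shift clearly beyond the scatter is expected, with only a slight lean towards less compound tolerated given the larger entering group. The expected change is a 1.8-fold lower number from compound 3 to compound 4 (0.25 log units; within the scatter) and its uncertainty is wide. For compound 4 the estimate is 40000 nM, with an expected range of 10000 nM to 100000 nM.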

Compound 4, half-maximal cytotoxic concentration: > 20000 nM
Compound 4 gave a limit, no number (the forecaster's own chance of this, stated with the estimate: 45%); the middle value does not contradict the limit.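

In this assay compound 4 gives > 20000 nM, which is a limit. The steps joining compound 4 to compound 1, compound 2 and compound 3 cannot be read, because each rests on a limit: the limit of > 20000 nM in this assay, at which 3 of the 4 values shown sit.

The compounds shown leave open how far octylsulfanyl on this aromatic carbon shifts the tolerated concentration relative to the ethoxy, isopropylamino or cyclopropylamino groups.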